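The source may hold more compounds than are shown below. What is called first, only, known or untested is meant among the compounds shown, and "the series" means these compounds.

Measured so far in a functional assay with Rattus norvegicus as the target; on this read-out higher numbers stand for weaker inhibition and lower numbers for stronger inhibition:
Compound 1, `Cc1cccc(C(=O)/C=C/c2ccncc2)c1`, gives 39000 nM.
Compound 2, `O=C(/C=C/c1ccncc1)c1ccccc1`, gives 49000 nM.
Compound 3, `CN(C)c1ccc(C(=O)/C=C/c2ccncc2)cc1`, gives 11000 nM.

Compound 2 has the highest number of the three. Its nearest neighbour is compound 1, which lies within the scatter of it, so no order between these two can be read. Compound 3 stands furthest away, and the step of a 4.5-fold lower number from compound 2 to compound 3 (0.65 log units; beyond the scatter) is the only one here that goes beyond the scatter.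

The new compound, compound 4, `N#Cc1cccc(C(=O)/C=C/c2ccncc2)c1`, differs from compound 2 by cyano in place of hydrogen on an aromatic carbon. Within the data shown here, two measured steps bear on this. The first, a 1.3-fold higher number from compound 1 to compound 2 (0.10 log units; within the scatter), shows that a small group on the same aromatic ring left the number essentially where it was. The second, a 4.5-fold lower number from compound 2 to compound 3 (0.65 log units; beyond the scatter), shows that a larger group on that ring can move the number by a modest amount, though on a different carbon. Among the measured compounds shown here, no measured compound carries a cyano group, so the size of its effect is unknown. The closest guide is compound 1 with 39000 nM, and on that basis the step is expected to stay within the scatter: compound 4 is estimated at 35000 nM, with a range from 12000 nM to 100000 nM. The step of a 1.4-fold lower number from compound 2 to compound 4 (0.15 log units; within the scatter) is thus expected to be small.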

Compound 4, half-maximal inhibitory concentration: 85000 nM
Compound 4: middle estimate off by 2.4-fold (0.39 log units), on the low side; measured number inside the range.
By their numbers in this assay, from the lowest: compound 3; then compounds 1, 2 and 4 (each within the scatter of the next, the first and the last beyond it).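

In this assay cyano, meta to a large group on the aromatic ring of carbon only, stays within the scatter when it takes the place of hydrogen (a 1.7-fold higher number from compound 2 to compound 4 (0.24 log units; within the scatter)), so this change on its own cannot be told from no change at all. Set against methyl on the same carbon, the picture sharpens: the swap of methyl for cyano gives a 2.2-fold higher number from compound 1 to compound 4 (0.34 log units; beyond the scatter), a modest step and the first difference at this position that can be read, although hydrogen cannot be separated from either of the other two groups. Nothing available explains why these two groups part in this way.

The compounds shown leave open whether dimethylamino at this position would give a number like that of compound 3, where it sits on a different carbon, or whether its step there is tied to that carbon. Going by these compounds, they also leave open how a carboxylic acid, a primary amine or a longer chain would read at this position, so the range of numbers this position can reach remains unknown.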